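Cyclobutyl for Trifluoroethyl, Tested Across Two Indole Cores

The source may report more compounds than this note shows. Statements on the series, on what has been measured and on what is new or still open speak of the compounds shown alone.

Measured so far:
Compound 1, `COc1cc(-c2nnc3c(OCC(F)(F)F)cc(-c4ccc5[nH]ccc5c4)cn23)cc(OC)c1OC`, gives 585 nM.
Compound 2, `COc1cc(-c2nnc3c(OC4CCC4)cc(-c4ccc5[nH]ccc5c4)cn23)cc(OC)c1OC`, gives 232 nM.
Compound 3, `COc1cc(-c2nnc3c(OCC(F)(F)F)cc(-c4ccc5c(ccn5C)c4)cn23)cc(OC)c1OC`, gives 614 nM.

All three were run in a functional assay on A549 cells (Homo sapiens) for antiproliferative activity, read by MTT assay, with a stated time of 48 h; a lower number here means a stronger inhibitor, a higher number a weaker inhibitor. Compound 1 and compound 2 share one core and differ by cyclobutyl in place of 2,2,2-trifluoroethyl on an oxygen on an aromatic ring; this gave a 2.5-fold lower number from compound 1 to compound 2 (0.40 log units; beyond the scatter). Compound 3 differs from compound 1 by methyl in place of hydrogen on an aromatic nitrogen, and the two read alike: a 1.0-fold higher number from compound 1 to compound 3 (0.02 log units; within the scatter), so the two cores cannot be told apart here.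

Compound 4, `COc1cc(-c2nnc3c(OC4CCC4)cc(-c4ccc5c(ccn5C)c4)cn23)cc(OC)c1OC`, has not yet been measured. It differs from compound 3 by cyclobutyl in place of 2,2,2-trifluoroethyl on an oxygen on an aromatic ring, the same change made from compound 1 to compound 2, and the place is described in identical words. Since the two cores behaved alike in this assay, the earlier step is expected to repeat: the estimated step is a 2.5-fold lower number from compound 3 to compound 4 (0.39 log units; beyond the scatter), beside a 2.5-fold lower number from compound 1 to compound 2 (0.40 log units; beyond the scatter). This rests on a single measured instance of the change, so the range is kept wide.

Compound 4 is therefore expected to give about 250 nM in this assay, most likely between 120 nM and 520 nM.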

Compound 4, half-maximal inhibitory concentration: 176 nM
The estimate for compound 4 lay 1.4-fold (0.15 log units) above the measured number, and the stated range covers the measured number.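

In this assay, cyclobutyl in place of 2,2,2-trifluoroethyl on the core of compound 3 gives a 3.5-fold lower number from compound 3 to compound 4 (0.54 log units; beyond the scatter), and this step agrees with the one on the core of compound 1: the same change on two cores in this assay, a 2.5-fold lower number (0.40 log units; beyond the scatter) from compound 1 to compound 2 and a 3.5-fold lower number (0.54 log units; beyond the scatter) from compound 3 to compound 4, 1.4-fold (0.14 log units) apart, within the scatter of two such steps. The methyl on the aromatic nitrogen again leaves the reading unresolved when cyclobutyl is present, with a 1.3-fold lower number from compound 2 to compound 4 (0.12 log units; within the scatter), so the two methyl steps also agree: the same change on two cores in this assay, a 1.0-fold higher number (0.02 log units; within the scatter) from compound 1 to compound 3 and a 1.3-fold lower number (0.12 log units; within the scatter) from compound 2 to compound 4, 1.4-fold (0.14 log units) apart, within the scatter of two such steps. Together these results show that the two changes carry over between these two cores in this assay, but they rest on a single pair of steps for each change and show neither why the cyclobutyl compounds read lower nor that the same would hold on any other core.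

The compounds shown leave open whether a longer chain such as n-butyl, or a chain ending in an amine, would follow cyclobutyl or 2,2,2-trifluoroethyl on that oxygen. They also leave open whether an ethyl group or a longer chain on the aromatic nitrogen would read like hydrogen and methyl.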